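Urea analogue of compound 3: expected cytotoxicity on lung cells

The compounds below may be only part of what the source reports. "The series", "measured", "known", "first", "only" and "open" are said of these compounds alone.

The series shares one core, shown for compound 1 `COc1cc(-c2nn(-c3cccc(NC(=O)c4cccc(C(F)(F)F)c4)c3)cc2-c2ccncc2)ccc1Cl`, compound 2 `COc1cc(-c2nn(-c3cccc(NC(=O)Nc4cccc(C(F)(F)F)c4)c3)cc2-c2ccncc2)ccc1Cl` and compound 3 `COc1cc(-c2nn(-c3cccc(NC(=O)c4ccc(Cl)c(C(F)(F)F)c4)c3)cc2-c2ccncc2)ccc1Cl`. In a functional assay on A549 cells (Homo sapiens) for inhibition, read by sulforhodamine B assay, with a stated time of 48 h (on this read-out lower numbers stand for higher toxicity in this test and higher numbers for lower toxicity in this test), compound 1 gives only a limit, > 50000 nM. Compound 2 likewise reaches only a limit in this assay, > 50000 nM. Compound 3 also stands at a limit in this assay, > 32500 nM. Compound 3 thus sits at the limit of > 32500 nM in this assay, at which 1 of the 3 values shown sits, while the other two sit at the limit of > 50000 nM in this assay, at which 2 of the 3 values shown sit, and no ordering among the three can be read. Compound 4 `COc1cc(-c2nn(-c3cccc(NC(=O)Nc4ccc(Cl)c(C(F)(F)F)c4)c3)cc2-c2ccncc2)ccc1Cl` differs from compound 3 by (4-chloro-3-(trifluoromethyl)phenyl)amino in place of 4-chloro-3-(trifluoromethyl)phenyl on a carbonyl carbon. The closest measured step is the corresponding change at the carbonyl carbon, a step that the two limits leave unreadable from compound 1 to compound 2. The steps a step that the two limits leave unreadable from compound 1 to compound 3 and a step that the two limits leave unreadable from compound 2 to compound 3 are equally unreadable. For the measured compounds named here, no measured step shows a readable size, so no direction beyond the scatter is expected. Compound 4 is expected to give 60000 nM, within 30000 nM to 200000 nM, most likely again as a limit. The expected step that the limit leaves unreadable from compound 3 to compound 4 is therefore estimated as about none.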

Compound 4, concentration lethal to 50% of the cells: > 32500 nM
Compound 4: a limit, no number (the forecaster's own chance of this, stated with the estimate: 85%); the middle value is on the limit's open side.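

In this assay compound 4 gives > 32500 nM, a limit and not a number. No new step can be read between compound 4 and compound 1, compound 2 or compound 3, as all four values are limits. The compounds shown leave open whether either the chloro or the change on the carbonyl carbon alters toxicity in this test.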